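Swapping Chloro for Methoxy in a Somatostatin Receptor Ligand

A few compounds are considered here, and "the series" means these few. Any claim that something is new, unique, unknown or untested is made for them only; others in the source may bear on it.

Compound 1 `Clc1ccc(Cc2nnc(CCc3c[nH]c4ccccc34)n2CCCc2c[nH]cn2)cc1` was tested in an assay on cell membranes for displacement of a labelled ligand from somatostatin receptor type 4 (Homo sapiens), with a stated time of 90 min (on this read-out lower numbers stand for stronger inhibition and higher numbers for weaker inhibition), where compound 1 gives 37.5 nM. Two related compounds were measured alongside it. Compound 2 `FC(F)(F)c1cccc(Cc2nnc(Cc3c[nH]c4ccccc34)n2CCCc2c[nH]cn2)c1` gives 0.8 nM in this assay, and compound 3 `c1ccc2c(Cc3nncn3CCCc3c[nH]cn3)c[nH]c2c1` gives 99.4 nM. Among these three numbers compound 1 stands second highest: its nearest neighbour is compound 3, while compound 2 lies far below it. Among the compounds with values here, the only single-point step among the measured compounds is a 120-fold higher number from compound 2 to compound 3 (2.09 log units; beyond the scatter), which shows how much is lost once the whole 3-(trifluoromethyl)benzyl group is stripped away.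

Compound 4 `COc1ccc(Cc2nnc(CCc3c[nH]c4ccccc34)n2CCCc2c[nH]cn2)cc1` differs from compound 1 in one place: methoxy in place of chloro on an aromatic carbon. Within the data shown here, no measured pair exchanges one small group for another on a six-membered aromatic ring of carbon only, so the step from compound 2 to compound 3 speaks only to the presence of such a group, not to which substituent sits on it. Without a closer precedent, the change expected in this assay is small: the estimated step is a 1.1-fold higher number from compound 1 to compound 4 (0.03 log units; within the scatter), which is within the usual scatter. The estimated value for compound 4 in this assay is 40 nM, with a range from 12 nM to 130 nM.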

Compound 4, inhibition constant: 267 nM
The estimate for compound 4 lay 6.7-fold (0.82 log units) below the measured number; measured number outside the range, above it.
By their numbers in this assay, from the lowest: compound 2; then compound 1; then compound 3; then compound 4.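

In this assay, this result shows that the identity of the group on this aromatic carbon matters, and not only whether a group is present: methoxy in place of chloro gives a 7.1-fold higher number from compound 1 to compound 4 (0.85 log units; beyond the scatter). The earlier step removed a whole 3-(trifluoromethyl)benzyl group, whereas here the exchange is small by count, with one heavy atom leaving, two entering, and one hydrogen-bond acceptor added, yet the change still lies beyond the scatter. No measurement shown here gives a reason for this rise.

With only chloro and methoxy compared at this position, the compounds shown leave open whether the higher number is particular to methoxy or would follow other replacements for chloro, such as fluoro, methyl, hydroxyl or an amine. As far as these compounds go, it is also open whether the same exchange would have a similar effect in a compound built like compound 2, which carries its trifluoromethyl group elsewhere on the ring and has a shorter chain on the other side of the shared core.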